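The source may hold more compounds than are shown below. What is called first, only, known or untested is meant among the compounds shown, and "the series" means these compounds.

Measured compounds:
compound 1, `Cc1c(CCC(=O)O)cccc1NC(=O)[C@H](c1ccc(CN2N=C(c3ccccc3)OCC2=O)cc1)C1CCCC1`, 110%
compound 2, `C[C@H]([C@H](C(=O)Nc1ccc(Cl)c(CC2(C(=O)O)CC2)c1)c1ccc(Cl)cc1)C(F)(F)F`, 1.2%
compound 3, `C[C@H]([C@H](C(=O)Nc1cc(CC2(C(=O)O)CC2)ccc1Cl)c1ccc(Cl)cc1)C(F)(F)F`, 63%

All three were read in an assay on CHO cells for activation of Guanylate cyclase soluble subunit alpha-1 (Rattus norvegicus), read by luminescence and cGMP accumulation, with a stated time of 6 min; on this read-out higher numbers stand for larger maximal responses and lower numbers for smaller maximal responses. Compound 3 stands second highest of the three numbers. Its nearest neighbour is compound 1, whose value lies higher by a margin beyond the scatter; its furthest is compound 2, whose value lies lower by a still larger margin, also beyond the scatter. Compounds 2 and 3 carry the same set of groups, yet their values sit far apart, so the arrangement on the aromatic ring bearing the amide nitrogen matters for the maximal response here.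

Compound 4, `C[C@H]([C@H](C(=O)Nc1cc(CC2(C(=O)O)CC2)ccc1F)c1ccc(Cl)cc1)C(F)(F)F`, has not yet been measured in this assay. It differs from compound 3 by fluoro in place of chloro on an aromatic carbon. The change sits ortho to a large group and para to the (1-carboxycyclopropyl)methyl group, and swaps one halogen for another of the same count of heavy atoms.

For the measured compounds named here, no measured pair shows this exchange, so no direct step is available. With a single-atom swap at an aromatic carbon, compound 4 is expected to stay close to compound 3, with a step of a number 8 percentage points lower from compound 3 to compound 4 (within the scatter) that is expected to lie within the usual scatter, leaning slightly downward. Compound 4 is therefore estimated at 55%, with a range from 25% to 90%.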

Compound 4, largest response reached (reported as efficacy), in percent of the reference or control that the assay uses: 34%
For compound 4 the middle estimate is 21 percentage points above the measured one, and the stated range covers the measured number.
By their numbers in this assay, from the lowest: compound 2; then compound 4; then compound 3; then compound 1.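

In this assay, fluoro in place of chloro on the aromatic carbon para to the (1-carboxycyclopropyl)methyl group gives a number 29 percentage points lower from compound 3 to compound 4 (beyond the scatter), so the maximal response responds to a single halogen exchange at this position. For the compounds shown here, the earlier compounds showed only that the arrangement of groups on this ring matters; this step adds that the identity of the halogen at this carbon matters too, with the heavy-atom count unchanged. No measurement shown accounts for the difference between the two halogens.

With only two halogens at this carbon, the series gives no trend for this position. From the compounds shown here alone, it remains open whether a methyl group, a methoxy group or a nitrile there would keep the response of compound 3 at 63%, and whether bromo would extend the difference seen between chloro and fluoro.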